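This account rests on a few compounds, and the source may have more. Where it says the series, first, only, none or still open, it means among the compounds named here.

Working notes on the series. Three compounds have been run so far: compound 1 `C/C(=C\c1cc(-c2ccc(F)cc2)co1)C(N)=O`, compound 2 `C/C(=C\c1cc(-c2ccc(F)nc2)co1)C(N)=O` and compound 3 `C/C(=C\c1cc(-c2ccc(C)cc2)cs1)C(N)=O`. In a functional assay on T-24 cells (Homo sapiens) for cytotoxicity, read by CCK-8 assay, with a stated time of 24 h (a higher number here means a weaker inhibitor, a lower number a stronger inhibitor), compound 1 gives > 50000 nM, which is a limit of the assay and not a number. In this assay compound 2 gives > 50000 nM, again a limit. In this assay compound 3 gives > 50000 nM, also a limit of the assay rather than a measured number. Compound 3 therefore cannot be ranked against the other two: the limit of > 50000 nM in this assay, at which 3 of the 3 values shown sit, so the three are indistinguishable on what is shown. Compound 4 `C/C(=C\c1cc(-c2ccc(S(C)(=O)=O)cc2)cs1)C(N)=O` differs from compound 3 by methylsulfonyl in place of methyl on an aromatic carbon. For the measured compounds named here, no step between measured compounds exists to set a scale for this change, and none of the measured compounds has produced a number in this assay. Compound 4 is expected to remain at the limit as well, with an estimated value of 50000 nM in a range of 20000 nM to 200000 nM. The estimated step from compound 3 to compound 4 is a number no higher from compound 3 to compound 4 (the limit leaves the size open), none beyond the scatter. That expectation rests on compound 3 sitting at > 50000 nM, a limit of the assay.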

Compound 4, half-maximal inhibitory concentration: > 50000 nM
Compound 4 was reported as a limit; the forecaster's own chance of this, stated with the estimate: 80%; the middle value lies on the limit itself.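

For the compounds shown here, no step from compound 3 to compound 4 can be read, because both compounds stand at a limit of the assay and not at a number: the limit of > 50000 nM in this assay, at which 4 of the 4 values shown sit. The compounds shown leave open whether any change to the shared core would give a measured number in this assay.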